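From oxan-4-yl to piperidin-4-yl on a shared core

This account rests on a few compounds, and the source may have more. Where it says the series, first, only, none or still open, it means among the compounds named here.

compound 1 `COc1cc(C(=O)N2CCCC2)ccc1-c1ccnc2[nH]c(C3CCOCC3)cc12` gives 0.8 L/kg
compound 2 `CC(C)n1cc(-c2ccnc3[nH]c(C4CCN(CC(=O)N5CCCCC5)CC4)cc23)ccc1=O` gives 8.1 L/kg

In an ADME assay (Rattus norvegicus, strain Han-wistar) for pharmacokinetics, at a dose of 1.5 umol/kg by the intravenous route (a lower number here means that more of the compound stays in the plasma, a higher number that more of the compound sits outside the plasma), compound 1 stands lowest of the two measured compounds at 0.8 L/kg and compound 2 gives 8.1 L/kg on the same read-out, a gap that lies beyond the scatter. Within the data shown here, compound 3 `COc1cc(C(=O)N2CCCC2)ccc1-c1ccnc2[nH]c(C3CCNCC3)cc12` keeps the core of compound 1 and carries piperidin-4-yl in place of oxan-4-yl on an aromatic carbon as its only change. Among the measured compounds shown here, no measured pair differs in one place alone, so the data hold no direct precedent for this step. For the measured compounds named here, compound 2 at 8.1 L/kg also bears a six-membered non-aromatic ring with nitrogen, and it is the only guide, though it differs from compound 1 in several places. A rise beyond the scatter is therefore expected, an estimated 6.3-fold higher number from compound 1 to compound 3 (0.80 log units; beyond the scatter) in this assay for this change. Compound 3 is estimated at 5 L/kg with 2 L/kg to 12 L/kg as the expected range.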

Compound 3, volume of distribution: 5.8 L/kg
For compound 3 the middle estimate is 1.2-fold (0.06 log units) below the measured one, and the stated range covers the measured number.
By their numbers in this assay, from the lowest: compound 1; then compounds 3 and 2 (each within the scatter of the next).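

Piperidin-4-yl in place of oxan-4-yl, on an aromatic carbon of a five-membered aromatic ring, gives a 7.3-fold higher number from compound 1 to compound 3 (0.86 log units; beyond the scatter) in this assay as the first step in this set with only one place changed. The exchange keeps the ring size and heavy-atom count, while ring oxygen gives way to ring nitrogen and a hydrogen-bond donor enters. No measurement shown here accounts for the size of this step.

From the compounds shown here alone, it remains open whether the number would stay this high with a methyl or acetyl group on the ring nitrogen, or with an open-chain amine at this place. Going by these compounds, whether the same exchange gives a similar step on another core also remains open.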